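Swapping the anilide ring for a pyrazine in a PDE4 inhibitor

A few compounds are considered here, and "the series" means these few. Any claim that something is new, unique, unknown or untested is made for them only; others in the source may bear on it.

Three compounds from this series share a core built from a methoxy-substituted benzamide. Compound 1 `COc1ccc(C(=O)Nc2c(F)cccc2Cl)cc1OC1CCCC1` carries a cyclopentyloxy group on that core and a 2-chloro-6-fluorophenyl ring on the amide nitrogen; in an assay on isolated protein for inhibition of phosphodiesterase 4A (Sus scrofa) (on this read-out higher numbers stand for weaker inhibition and lower numbers for stronger inhibition), compound 1 gives 240 nM. Compound 2 `COc1ccc(C(=O)Nc2c(C)cccc2Cl)cc1OC1CCCC1` differs only in that a methyl replaces the fluoro on that ring, and compound 2 gives 100 nM. That change is a 2.4-fold lower number from compound 1 to compound 2 (0.38 log units; beyond the scatter). Compound 3 `COc1ccc(C(=O)Nc2c(F)cccc2F)cc1` lacks the cyclopentyloxy group and carries two fluoro atoms on the ring; compound 3 gives 37000 nM, the weakest number in the set by a wide margin. Compound 2 thus stands lowest of the three values.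

Compound 4 `COc1ccc(C(=O)Nc2cnccn2)cc1OC1CCCC1` keeps the cyclopentyloxy core of compound 2 but exchanges the whole ring on the amide nitrogen: pyrazin-2-yl in place of 2-chloro-6-methylphenyl on an amide-type nitrogen. Among the compounds with values here, only the step from compound 1 to compound 2 touches the same ring, and it was modest, covering a change of one substituent rather than the entire ring. Within the data shown here, no measured step covers losing both substituents along with the carbon-only ring, so the expectation rests on weak footing. Compound 4 is expected to come in weaker than compound 2, with a step of a 25-fold higher number from compound 2 to compound 4 (1.40 log units; beyond the scatter), giving an estimated 2500 nM, within a range from 400 nM to 15000 nM.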

Compound 4, half-maximal inhibitory concentration: 250 nM
Beside the measured number, compound 4's estimate is 10-fold (1.00 log units) above it; the whole stated range lies above it.
By their numbers in this assay, from the lowest: compound 2; then compounds 1 and 4 (each within the scatter of the next); then compound 3.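

Within the data shown here, until now, the only change on this ring was one substituent, so it was unclear how much the rest of the 2-chloro-6-methylphenyl group mattered on an amide-type nitrogen. Replacing the entire group with pyrazin-2-yl removes the chlorine, the methyl and the carbon-only ring together, yet the step is only modest, at a 2.5-fold higher number from compound 2 to compound 4 (0.40 log units; beyond the scatter), and the comparison with the fluoro analogue gives a 1.0-fold higher number from compound 1 to compound 4 (0.02 log units; within the scatter). In this assay, then, on this cyclopentyloxy core, a substituted carbon-only ring is not needed for compound 4 to give 250 nM, although compound 2 still gives the lowest number, and nothing available explains why so large an exchange produces so small a shift.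

The compounds shown cannot separate the loss of the chlorine and methyl from the introduction of the ring nitrogens, a question that an unsubstituted phenyl or a pyridin-2-yl group on the same nitrogen would address. Going by these compounds, it also remains open whether adding a methyl or chloro to the pyrazin-2-yl ring would lower the number further or raise it.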